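This account rests on a few compounds, and the source may have more. Where it says the series, first, only, none or still open, it means among the compounds named here.

Measured compounds:
compound 1 `CCN(CCCCCCn1sc2cc(OC)c(OC)cc2c1=O)Cc1ccccc1`: 8200 nM
compound 2 `CCN(CCCCCCn1sc2cc(OC)c(OC)cc2c1=O)Cc1ccccc1N(C)C`: 3400 nM

In an assay on isolated protein for inhibition of Amine oxidase [flavin-containing] A (Homo sapiens), read by fluorescence, with a stated time of 30 min (on this read-out higher numbers stand for weaker inhibition and lower numbers for stronger inhibition), compound 2 gives the lowest of the two numbers, and its nearest neighbour is compound 1, with a modest change a 2.4-fold lower number from compound 1 to compound 2 (0.38 log units; beyond the scatter). Compound 3 `CCN(CCCCCCn1sc2cc(OC)c(OC)cc2c1=O)Cc1ccc(N(C)C)cc1` differs from compound 2 in one place: 4-(dimethylamino)phenyl in place of 2-(dimethylamino)phenyl on a saturated chain carbon bound to an amine nitrogen. For the measured compounds named here, the single measured step, a 2.4-fold lower number from compound 1 to compound 2 (0.38 log units; beyond the scatter), concerns adding the dimethylamino group, not moving it, so it bears only loosely on this change. Compound 3 is therefore expected to stay close to compound 2, with an estimated step of a 1.0-fold higher number from compound 2 to compound 3 (0.01 log units; within the scatter) within the scatter. The estimate for compound 3 is 3500 nM, ranging from 1500 nM to 8000 nM.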

Compound 3, half-maximal inhibitory concentration: 7100 nM
Compound 3: the middle estimate sits 2.0-fold (0.31 log units) below what was measured; the range from low to high includes it.
By their numbers in this assay, from the lowest: compound 2; then compounds 3 and 1 (each within the scatter of the next).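

In this assay, the place of the dimethylamino group counts: 4-(dimethylamino)phenyl in place of 2-(dimethylamino)phenyl gives a 2.1-fold higher number from compound 2 to compound 3 (0.32 log units; beyond the scatter). Added as 4-(dimethylamino)phenyl, the group gives only a 1.2-fold lower number from compound 1 to compound 3 (0.06 log units; within the scatter), so among these compounds the step beyond the scatter from adding dimethylamino belongs to the 2-(dimethylamino)phenyl form alone. Nothing available accounts for this difference. Going by these compounds, whether 3-(dimethylamino)phenyl would read closer to 2-(dimethylamino)phenyl or to 4-(dimethylamino)phenyl stays open. So does whether 2-methoxyphenyl or 2-(diethylamino)phenyl would keep the lower number.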